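Compound 2 to compound 3 at the assay limit

A few compounds are considered here, and "the series" means these few. Any claim that something is new, unique, unknown or untested is made for them only; others in the source may bear on it.

Measured in a functional assay on UACC-257 cells (Homo sapiens) for inhibition, read by sulforhodamine B assay, with a stated time of 48 h; a lower number here means a stronger inhibitor of growth, a higher number a weaker inhibitor of growth:
Compound 1 `Cc1ccc(C2=NN(c3ccc(S(C)(=O)=O)cc3)C(=O)CC2)cc1` gives > 100000 nM
Compound 2 `Cc1cc(O)ccc1C1=NN(c2ccc(S(C)(=O)=O)cc2)C(=O)CC1` gives > 100000 nM

Compound 2 stands at > 100000 nM, which is a limit and not a number. Among the measured compounds shown here, the only other value, that of compound 1, is also a limit. Both measured compounds therefore sit at one ceiling, (the limit of > 100000 nM in this assay, at which 2 of the 2 values shown sit).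

Compound 3 `CCc1ccc(C2=NN(c3ccc(S(C)(=O)=O)cc3)C(=O)CC2)cc1` is still unmeasured. It carries 4-ethylphenyl in place of the 4-hydroxy-2-methylphenyl of compound 2, on a carbon with a double bond to nitrogen: 4-ethylphenyl in place of 4-hydroxy-2-methylphenyl on a carbon with a double bond to nitrogen.

For the measured compounds named here, the one measured step that bears on this change is a step that the two limits leave unreadable from compound 1 to compound 2, so it offers no size to carry over. Going by the values given here, nothing measured so far shows a change at this place moving a value off the limit. No step beyond the scatter is therefore expected, in either direction, and compound 3 is expected to stay at or close to the limit. The expected step is an at least 1.1-fold lower number from compound 2 to compound 3 (0.04 log units; that floor lies within the scatter). For compound 3 the estimate is 90000 nM, with an expected range from 30000 nM to 100000 nM.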

Compound 3, concentration for total growth inhibition: 61500 nM
Estimate against measurement, compound 3: 1.5-fold (0.17 log units) above; the measured number falls inside the stated range.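

In this assay, among the compounds shown here, compound 3, which carries 4-ethylphenyl, gives 61500 nM, the only value among the three compounds that is a number and not a limit, so a change at this place, on a carbon with a double bond to nitrogen, can bring a reading inside the range of the assay. On these data alone, putting 4-ethylphenyl in place of 4-hydroxy-2-methylphenyl gives an at least 1.6-fold lower number from compound 2 to compound 3 (0.21 log units; that floor lies within the scatter), and putting methyl in place of hydrogen on the saturated chain carbon bound to an aromatic carbon gives an at least 1.6-fold lower number from compound 1 to compound 3 (0.21 log units; that floor lies within the scatter); each of these is only a floor, so the true size of either step stays unknown. The step between the two other compounds cannot be read, and both of them remain at the ceiling: the limit of > 100000 nM in this assay, at which 2 of the 3 values shown sit.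

The compounds shown leave open whether a longer chain, such as propyl or butyl, in place of the ethyl would give a lower number still or return the reading to the limit. They also leave open what an amine or a carboxylic acid on the phenyl ring would do at this place.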